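From hydroxy to methoxy: a small expected step

The compounds below may be only part of what the source reports. "The series", "measured", "known", "first", "only" and "open" are said of these compounds alone.

In a functional assay on A549 cells (Homo sapiens) for cytotoxicity, read by sulforhodamine B assay, with a stated time of 48 h (on this read-out higher numbers stand for weaker inhibition and lower numbers for stronger inhibition), compound 1 `COc1cc(/C=C/C(=O)c2cccc(-c3cccc(F)c3)c2)ccc1O` gives 9900 nM and so sits within the scatter of its two measured relatives. Compound 2 `COc1cccc(/C=C/C(=O)c2cccc(-c3cccc(F)c3)c2)c1OC` gives 8900 nM and compound 3 `COc1ccccc1/C=C/C(=O)c1cccc(-c2cccc(F)c2)c1` gives 15500 nM on the same read-out, so compound 1 holds no clear rank among them.

Compound 4 `COc1ccc(/C=C/C(=O)c2cccc(-c3cccc(F)c3)c2)cc1OC` differs from compound 1 by methyl in place of hydrogen on an oxygen on an aromatic ring and so carries methyl in place of hydrogen on an oxygen on an aromatic ring, which turns hydroxy to methoxy.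

For the measured compounds named here, the only measured step involving a methoxy group is a 1.7-fold higher number from compound 2 to compound 3 (0.24 log units; within the scatter) and that step, hydrogen in place of methoxy, lies within the scatter. It removes a methoxy rather than turning a hydroxy into one, so it is only an indirect guide. The change itself has not been measured here. No step beyond the scatter is therefore expected, and the estimated step is a 1.0-fold higher number from compound 1 to compound 4 (0.00 log units; within the scatter) with no firm direction.

In this assay compound 4 is expected at 10000 nM with a range from 5000 nM to 20000 nM as the estimate.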

Compound 4, half-maximal inhibitory concentration: 1940 nM
Compound 4: middle estimate off by 5.2-fold (0.71 log units), on the high side; the measured number lies below the stated range.
By their numbers in this assay, from the lowest: compound 4; then compounds 2, 1 and 3 (each within the scatter of the next).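

Turning this hydroxy into methoxy is not a silent change in this assay: the result is a 5.1-fold lower number from compound 1 to compound 4 (0.71 log units; beyond the scatter), the first step in this set that clearly exceeds the scatter. The earlier step, which removed a methoxy from a different compound, stayed within the scatter and never touched a hydroxy, so it could not reveal that the group on this oxygen matters. Nothing shown here accounts for the size of the step, which rests on this one pair of compounds.

As far as these compounds go, whether a longer chain such as ethoxy on this oxygen would push the number lower still, or an amine in place of the methoxy would bring it back up, remains open. Also open, from the compounds shown here alone, is whether the same change would have a similar effect on other compounds.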